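Compound 1 to compound 4: a tert-butyl regioisomer

This account rests on a few compounds, and the source may have more. Where it says the series, first, only, none or still open, it means among the compounds named here.

The series shares one core, carried by compound 1 `COc1cc(NC(=O)Nc2cc(Nc3cccc(C(C)(C)C)c3)ncn2)cc(OC)c1`. In a functional assay on HCC827 cells (Homo sapiens) for inhibition, read by MTT assay, with a stated time of 48 h, tested at 10 uM (on this read-out lower numbers stand for less inhibition and higher numbers for more inhibition at the one concentration tested (going by the name of the read-out)), compound 1 gives 48.7%. Compound 2 `CC(C)(C)c1cccc(Nc2cc(NC(=O)Nc3c(Cl)cccc3Cl)ncn2)c1` gives 37.3% in this assay, and compound 3 `COc1cc(NC(=O)Nc2cc(Nc3cc(C(F)(F)F)ccc3OC)ncn2)cc(OC)c1` gives 59.7%. Compound 1 thus stands second highest of the three numbers: compound 3 lies higher and compound 2 lower, both beyond the scatter. Going by the values given here, the only single-point step measured so far, a number 11.4 percentage points lower from compound 1 to compound 2 (beyond the scatter), concerns the aryl on the amide-type nitrogen, not the aryl on the ring nitrogen.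

Compound 4 `COc1cc(NC(=O)Nc2cc(Nc3ccc(C(C)(C)C)cc3)ncn2)cc(OC)c1` differs from compound 1 as follows: 4-(tert-butyl)phenyl in place of 3-(tert-butyl)phenyl on a nitrogen on an aromatic ring. Among the compounds with values here, no measured step alters this aryl alone; compound 3 changes it but by more than one substitution, so its value can only be read alongside that of compound 1, where the pair shows a higher number for compound 3. Within the data shown here, with no direct precedent, no step beyond the scatter is expected, a number 3.7 percentage points lower from compound 1 to compound 4 (within the scatter). Compound 4 is therefore estimated at 45% in this assay, within 30% to 62%.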

Compound 4, a percentage reported as inhibition, at one concentration (the size of the read-out at that concentration, not a potency): 32.7%
Compound 4: middle estimate off by 12.3 percentage points, on the high side; low and high end bracket the measured number.
By their numbers in this assay, from the lowest: compounds 4 and 2 (each within the scatter of the next); then compound 1; then compound 3.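

With 4-(tert-butyl)phenyl in place of 3-(tert-butyl)phenyl, the aryl on the ring nitrogen now has its first single-place step, a number 16 percentage points lower from compound 1 to compound 4 (beyond the scatter), in this assay on the shared core. The two groups hold the same atoms, joined differently, so this position responds to how the tert-butyl group is attached to the aryl, not only to which atoms the group contains. No evidence at hand explains this step.

On these data alone, it remains open whether the same change would give a similar step with the 2,6-dichlorophenyl of compound 2 on the amide-type nitrogen. Also open, as far as these compounds go, is how this position would respond if an amine, a carboxylic acid or an isopropyl group took the place of tert-butyl on the aryl.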